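Pyridin-4-yl for Pyridin-3-yl in Two Hydrazone Pairs

The source may report more compounds than this note shows. Statements on the series, on what has been measured and on what is new or still open speak of the compounds shown alone.

Measured so far:
compound 1, `O=C(N/N=C/c1cccnc1)c1cccnc1Nc1cccc(C(F)(F)F)c1`: 62.4%
compound 2, `O=C(N/N=C/c1ccncc1)c1cccnc1Nc1cccc(C(F)(F)F)c1`: 65.2%
compound 3, `CNc1ncccc1C(=O)N/N=C/c1cccnc1`: 43.7%

In a functional assay on the whole organism (strain Wistar) for inhibition, with Rattus norvegicus as the target, read by paw edema, with a stated time of 2 h, at a dose of 10 mg/kg by the intraperitoneal route (on this read-out higher numbers stand for more inhibition at the one dose given (going by the name of the read-out) and lower numbers for less inhibition), compound 1 gives 62.4% and compound 2 gives 65.2%. The two differ by pyridin-4-yl in place of pyridin-3-yl on a carbon with a double bond to nitrogen, and the step is a number 2.8 percentage points higher from compound 1 to compound 2 (within the scatter), so the two values cannot be told apart. Compound 3 gives 43.7% in this assay, the lowest of the three numbers and beyond the scatter from both others; the difference between its core and that of compound 1 is not broken down here. Compound 4, `CNc1ncccc1C(=O)N/N=C/c1ccncc1`, is not yet measured and carries the same change, (pyridin-4-yl in place of pyridin-3-yl on a carbon with a double bond to nitrogen), at a place described in the same words.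

Compound 4 is therefore expected to stay near compound 3, with a step of a number 2.3 percentage points higher from compound 3 to compound 4 (within the scatter), because the same change gave only a number 2.8 percentage points higher from compound 1 to compound 2 (within the scatter). Compound 4 is estimated at 46%, between 33% and 59%.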

Compound 4, a percentage reported as inhibition, in the whole organism at one dose (the size of the read-out at that dose, not a potency): 60.4%
Compound 4: middle estimate off by 14.4 percentage points, on the low side; the whole stated range lies below it.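

In this assay, pyridin-4-yl in place of pyridin-3-yl on the second core gave a number 16.7 percentage points higher from compound 3 to compound 4 (beyond the scatter). Set beside the earlier step, this one cannot be told apart from it, so the data give no sign that the change behaves differently on the two cores: the same change on two cores in this assay, a number 2.8 percentage points higher (within the scatter) from compound 1 to compound 2 and a number 16.7 percentage points higher (beyond the scatter) from compound 3 to compound 4, 13.9 percentage points apart, within the scatter of two such steps This does not show that the step has one fixed size, since only the second step lies beyond the scatter and two cores are a narrow basis for any other core in the series.

The compounds shown leave open how a plain phenyl ring would compare with either pyridine on the same carbon. They also leave open how the change would fare on a core carrying a longer alkyl chain on the amine.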